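The compounds below may be only part of what the source reports. "The series", "measured", "known", "first", "only" and "open" are said of these compounds alone.

Measured so far in an ADME assay on the whole organism (Rattus norvegicus, strain Wistar Han) for pharmacokinetics, read by LC-MS, with a stated time of 7 h; a lower number here means slower removal, a higher number faster removal of the compound:
- compound 1 `CNC(=O)c1cc(C(=O)N[C@H]2[C@@H]3COC[C@@H]32)c([C@@H](C)c2ccccc2)o1`, which gives 55 mL/min/kg
- compound 2 `CNC(=O)c1cc(C(=O)N[C@H]2[C@@H]3C[C@@H](O)C[C@@H]32)n([C@@H](C)c2cccc(Cl)c2)n1`, which gives 21 mL/min/kg

Compound 1 has the higher of the two numbers, and the gap to compound 2 is beyond the scatter. Compound 3 `CNC(=O)c1cc(C(=O)N[C@H]2[C@@H]3C[C@@H](O)C[C@@H]32)c([C@@H](C)c2ccccc2)o1` has not yet been measured in this assay. It differs from compound 1 in one place: a group of 7 heavy atoms (6 carbon, 1 oxygen; one three-membered non-aromatic ring of carbon only, one five-membered non-aromatic ring of carbon only) in place of a group of 6 heavy atoms (5 carbon, 1 oxygen; one three-membered non-aromatic ring of carbon only, one five-membered non-aromatic ring with 1 hetero atom), on an amide-type nitrogen. For the measured compounds named here, no step between measured compounds covers this change, and compound 2 differs in more than this one place, so its value can only be noted. For the step from compound 1 to compound 3 a moderate drop is expected, a 1.6-fold lower number from compound 1 to compound 3 (0.20 log units; within the scatter). Compound 3 is therefore estimated at 35 mL/min/kg, between 18 mL/min/kg and 65 mL/min/kg.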

Compound 3, clearance: 41 mL/min/kg
Estimate against measurement, compound 3: 1.2-fold (0.07 log units) below; low and high end bracket the measured number.
By their numbers in this assay, from the lowest: compounds 2, 3 and 1 (each within the scatter of the next, the first and the last beyond it).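

On the amide-type nitrogen, the group with a five-membered non-aromatic ring of carbon only and 1 hydrogen-bond donor can stand in place of the group with a five-membered non-aromatic ring with 1 hetero atom, and in this assay this gives only a small step (a 1.3-fold lower number from compound 1 to compound 3 (0.13 log units; within the scatter)). For the compounds shown here, this is the first one-place comparison at this position, and the change stays within the scatter. No measurement bears on the reason for this result. As far as these compounds go, whether an amine or a carboxylic acid on this ring would give a step beyond the scatter stays open, as does how the same change behaves on the core of compound 2.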